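The source may report more compounds than this note shows. Statements on the series, on what has been measured and on what is new or still open speak of the compounds shown alone.

Working notes on the series. Compound 1 `C=CC(C)(C)c1[nH]c2ccccc2c1/C=C1\NC(=O)[C@@](CO)(OC)NC1=O`, compound 2 `C=CC(C)(C)c1[nH]c2ccccc2c1/C=C1\NC(=O)[C@H](C)NC1=O` and compound 3 `C=CC(C)(C)c1[nH]c2ccccc2c1/C=C1\NC(=O)[C@H](CO)NC1=O` are the measured members; compound 4 `C=CC(C)(C)c1[nH]c2ccccc2c1/C=C1\NC(=O)[C@@](C)(OC)NC1=O` is not yet measured. In an ADME assay on MDCK cells (Canis lupus familiaris) for cytotoxicity, read by CellTiter-Glo, with a stated time of 40 h (on this read-out higher numbers stand for lower toxicity in this test and lower numbers for higher toxicity in this test), compound 1 gives > 200000 nM, which is a limit of the assay and not a number. In this assay compound 2 gives > 200000 nM, again a limit. In this assay compound 3 gives > 200000 nM, also a limit.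

Among the compounds with values here, the one pair that differs in a single place is compound 3 and compound 2. The change is hydrogen in place of hydroxy on a saturated chain carbon bound to a saturated ring carbon. The step it made is a step that the two limits leave unreadable from compound 3 to compound 2; this rests on (the limit of > 200000 nM in this assay, at which 3 of the 3 values shown sit), so nothing about its size can be read. Compound 1 and compound 3 differ in more than one place, and the difference between the two cores is not broken down here.

Compound 4 comes from compound 1 by hydrogen in place of hydroxy on a saturated chain carbon bound to a saturated ring carbon. The place line is word for word that of the change from compound 3 to compound 2, so it is the same change, made a second time in the series. The step from compound 1 to compound 4 is expected to be a step that the limit leaves unreadable from compound 1 to compound 4 in this assay, resting on the unreadable step that the two limits leave unreadable from compound 3 to compound 2 and on compound 1 already standing at > 200000 nM. Compound 4 is therefore expected to give about 250000 nM, within 100000 nM to 700000 nM, most likely reported only as a limit.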

Compound 4, half-maximal cytotoxic concentration: > 200000 nM
Compound 4: no number, only a limit; the forecaster's own chance of this, stated with the estimate: 85%; the middle value lies beyond the limit too.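

No new step can be read from compound 1 to compound 4 in this assay, as both values are limits of the assay and not numbers: the limit of > 200000 nM in this assay, at which 4 of the 4 values shown sit.

The compounds shown leave open whether hydrogen in place of hydroxy on a saturated chain carbon bound to a saturated ring carbon changes the read-out at all, and at what concentration any of them would become toxic to these cells.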